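The compounds below may be only part of what the source reports. "The series", "measured", "known", "first", "only" and "open" are said of these compounds alone.

Measured so far:
compound 1, `CC(=O)c1cc(-c2ccccc2)cc2cc(-c3ccc(F)cc3)[nH]c12`, 76.9%
compound 2, `COc1ccc(-c2cc(C(C)=O)c3[nH]c(-c4ccc(F)cc4)cc3c2)cc1`, 46.5%

For the measured compounds named here, compound 2 holds the lowest of the two numbers so far in a functional assay on HeLa cells (Homo sapiens) for cytotoxicity, read by MTT assay, with a stated time of 2 days, tested at 10 uM; on this read-out lower numbers stand for a stronger effect and higher numbers for a weaker effect at the one concentration tested; its nearest neighbour is compound 1, whose value in this assay, 76.9%, lies higher by a margin beyond the scatter. Going by the values given here, the single step that connects the two, a number 30.4 percentage points lower from compound 1 to compound 2 (beyond the scatter), was a large one, brought about by methoxy in place of hydrogen on an aromatic carbon.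

Compound 3, `COc1ccc(-c2cc(C(C)=O)c3[nH]c(-c4ccc(OC)cc4)cc3c2)cc1`, has not yet been measured in this assay. It differs from compound 2 as follows: methoxy in place of fluoro on an aromatic carbon. Among the compounds with values here, the only measured step also introduced a methoxy, but it replaced hydrogen and sat on a different ring, so it bears on the present change only loosely: it shows that adding a methoxy to this shared core once lowered the number by a large amount, yet the group that leaves here is fluoro, for which no comparison exists. A small further fall is therefore expected, within or close to the scatter, rather than another large one. On that basis compound 3 is estimated at 42%, with a range from 25% to 60%, which corresponds to an expected step of a number 4.5 percentage points lower from compound 2 to compound 3 (within the scatter).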

Compound 3, a percentage reported as activity, at one concentration (the size of the read-out at that concentration, not a potency): 37.1%
The estimate for compound 3 lay 4.9 percentage points above the measured number; measured number inside the range.
By their numbers in this assay, from the lowest: compounds 3 and 2 (each within the scatter of the next); then compound 1.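

In this assay, replacing 4-fluorophenyl with 4-methoxyphenyl gave a number 9.4 percentage points lower from compound 2 to compound 3 (within the scatter), so at this place, para to a large group, the fluoro and methoxy compounds cannot be told apart. For the compounds shown here, this is the first view of this position, since the earlier step, a number 30.4 percentage points lower from compound 1 to compound 2 (beyond the scatter), put a methoxy in place of hydrogen on the other aryl ring; the entry of a methoxy on the shared core therefore does not give a change beyond the scatter in both cases, at least when it replaces fluoro here. The data give no measured explanation for why the two steps differ in size.

The compounds shown leave open whether this position responds at all, since only fluoro and methoxy appear there, and a hydrogen, a hydroxyl group, an amine or a carboxylic acid might read differently. They also leave open whether a second methoxy contributes anything in its own right, as the comparison here starts from fluoro rather than from the unsubstituted phenyl ring.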